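This account rests on a few compounds, and the source may have more. Where it says the series, first, only, none or still open, it means among the compounds named here.

Of the compounds shown here, two have so far been read in an ADME assay on HeLa cells (Homo sapiens) for cytotoxicity, read by crystal violet staining, with a stated time of 72 h; a higher number here means that more compound is tolerated, a lower number that less compound is tolerated. Compound 1 `CCOC(=O)c1cc(CCCOc2ccc(-c3noc(C(F)(F)F)n3)cc2OC)on1` gives > 100000 nM, which is a limit of the assay and not a number. For the measured compounds named here, compound 2 `Cc1cc(-c2noc(C(F)(F)F)n2)cc(C)c1OCCCc1cc(C(=O)OC(C)C)no1` gives 17900 nM, the only actual number available. Compound 3 `Cc1cc(-c2noc(C(F)(F)F)n2)cc(C)c1OCCCc1cc(-c2ccc(OC(F)(F)F)cc2)no1` has not yet been measured. It carries 4-(trifluoromethoxy)phenyl in place of isopropoxycarbonyl on an aromatic carbon of the five-membered aromatic ring with 1 nitrogen and 1 oxygen (4-(trifluoromethoxy)phenyl in place of isopropoxycarbonyl on an aromatic carbon). Going by the values given here, no step between measured compounds covers this exchange, so the expectation rests on compound 2 at 17900 nM alone, and no step beyond the scatter is expected in this assay. The expected change is small, estimated as a 1.1-fold higher number from compound 2 to compound 3 (0.05 log units; within the scatter). For compound 3 the estimated value is 20000 nM, with an expected range of 6000 nM to 80000 nM.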

Compound 3, half-maximal cytotoxic concentration: > 100000 nM
Compound 3 was reported as a limit; the forecaster's own chance of this, stated with the estimate: 25%; middle value at least 5.0-fold (0.69 log units) from the limit.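

On an aromatic carbon of the five-membered aromatic ring with 1 nitrogen and 1 oxygen, 4-(trifluoromethoxy)phenyl in place of isopropoxycarbonyl gives in this assay an at least 5.5-fold higher number from compound 2 to compound 3 (0.74 log units; beyond the scatter), the only step at a single place in the compounds shown. On this shared core, isopropoxycarbonyl at this position is therefore not needed for a reading at the limit, and compound 3 gives > 100000 nM, which is a limit of the assay and not a number. The step is therefore only a lower bound on the size of this change: the limit of > 100000 nM in this assay, at which 2 of the 3 values shown sit.

As far as these compounds go, how far compound 3 lies past the limit remains open, as does whether the number for compound 2 is specific to isopropoxycarbonyl or shared by other groups at this position. An amine, a carboxylic acid or an unsubstituted phenyl there would test this in this assay.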